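The source may report more compounds than this note shows. Statements on the series, on what has been measured and on what is new or still open speak of the compounds shown alone.

Compound 1 `Cc1cccc(NC(=O)COc2ccc(/C=C3\SC(=O)NC3=O)cc2)n1` and compound 2 `O=C(COc1ccc(/C=C2\SC(=O)NC2=O)cc1)Nc1ccccc1` share one core and differ only in the group on an amide-type nitrogen. In a functional assay on KB cells (Homo sapiens) for inhibition (a higher number here means a weaker inhibitor of growth, a lower number a stronger inhibitor of growth), compound 1 gives 75000 nM. In this assay compound 2 reaches only a limit, > 100000 nM, and not a number. The step of an at least 1.3-fold higher number from compound 1 to compound 2 (0.12 log units; that floor lies within the scatter) is therefore a floor rather than a measured size, and that floor rests on (the limit of > 100000 nM in this assay, at which 1 of the 2 values shown sits). Compound 3 `O=C(COc1ccc(/C=C2\SC(=O)NC2=O)cc1)Nc1ccc(F)cc1F` is the next member of the series. It differs from compound 2 by 2,4-difluorophenyl in place of phenyl on an amide-type nitrogen. Within the data shown here, no measured step shows what two fluorines on this ring do in this assay, and the one step at this place, an at least 1.3-fold higher number from compound 1 to compound 2 (0.12 log units; that floor lies within the scatter), ends at a limit, so no change beyond the scatter is expected. Compound 3 is therefore expected to give 100000 nM in this assay, within 40000 nM to 300000 nM, an expected step of a number no higher from compound 2 to compound 3 (the limit leaves the size open) that most likely again ends at the limit.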

Compound 3, concentration for 50% growth inhibition: > 100000 nM
Compound 3: a limit, no number; the forecaster's own chance of this, stated with the estimate: 70%; the middle value lies on the limit itself.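

In this assay compound 3 also stops at a limit, > 100000 nM, which is not a number. Adding two fluorines to the phenyl group therefore gives no measurable value here, and the comparison of compound 2 with compound 3 cannot be read, since both ends are limits: the limit of > 100000 nM in this assay, at which 2 of the 3 values shown sit.

Among these compounds, the one readable comparison is an at least 1.3-fold higher number from compound 1 to compound 3 (0.12 log units; that floor lies within the scatter), so 2,4-difluorophenyl in place of 6-methylpyridin-2-yl on the amide-type nitrogen shows no change that can be told from the scatter.

The compounds shown leave open how far the true values of compound 2 and compound 3 lie past the limit. They also leave open whether a phenyl group carrying an amine or a carboxylic acid on this nitrogen would give a value that can be read.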